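Chloro Removal Between Ring Nitrogens in a Purine-Type Pair

The source may report more compounds than this note shows. Statements on the series, on what has been measured and on what is new or still open speak of the compounds shown alone.

Working notes on a small set sharing one core. Compound 1 `Nc1nc(Cl)c2ncn(Cc3ccccc3CCl)c2n1` and compound 2 `ClCc1cccc(Cn2cnc3nc(Cl)nc(Cl)c32)c1` are measured; compound 3 `ClCc1cccc(Cn2cnc3ncnc(Cl)c32)c1` is not yet measured. In a functional assay on RPMI-8226 cells (Homo sapiens) for cytotoxicity, read by sulforhodamine B assay, with a stated time of 48 h (on this read-out lower numbers stand for higher toxicity in this test and higher numbers for lower toxicity in this test), compound 1 returns only a limit, > 100000 nM. In this assay compound 2 likewise returns only a limit, > 100000 nM. Both readings sit at the limit of > 100000 nM in this assay, at which 2 of the 2 values shown sit, so compound 2 stands at the top of what is recorded, without a number of its own. Compound 3 differs from compound 2 by hydrogen in place of chloro on an aromatic carbon. Going by the values given here, no step between measured compounds is available for comparison. In this assay no step beyond the usual scatter is expected from compound 2 to compound 3, in either direction. Compound 3 is estimated at 150000 nM, within 50000 nM to 500000 nM, and most likely reported again only as a limit. The step this estimate means, a step that the limit leaves unreadable from compound 2 to compound 3, is expected to lie within the scatter.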

Compound 3, concentration lethal to 50% of the cells: 89100 nM
For compound 3 the middle estimate is 1.7-fold (0.23 log units) above the measured one; the range from low to high includes it.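

With hydrogen in place of chloro on an aromatic carbon between two ring nitrogen atoms, compound 3 gives a number of its own in this assay, which neither earlier compound does. The change gives an at least 1.1-fold lower number from compound 2 to compound 3 (0.05 log units; that floor lies within the scatter). That step is only a floor, and its true size cannot be read because compound 2 carries only a limit: the limit of > 100000 nM in this assay, at which 2 of the 3 values shown sit.

On these data alone, whether a methoxy group or a methyl group on this same carbon would also give a number in this assay, and how large it would be, stays open. Also open is what the remaining chloro contributes, since no compound shown differs from compound 3 in that one place alone.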